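The compounds below may be only part of what the source reports. "The series", "measured", "known", "first", "only" and "open" are said of these compounds alone.

Series notes. Compound 1 `CN1CCCN(Cc2ccc(-c3ccccc3)cc2)CC1` gives 3700 nM in an assay on isolated protein for binding affinity to choline kinase alpha (Homo sapiens), read by surface plasmon resonance (a higher number here means weaker binding, a lower number tighter binding), the highest of the two numbers measured; compound 2 `CN1CCCN(Cc2ccc(-c3ccc(CN4CCCN(C)CC4)c(F)c3F)cc2)CC1` gives 21 nM, far lower, but the two structures differ in more than one place, so no single step can be read from that pair. Compound 3 `COc1ccc(-c2ccc(CN3CCCN(C)CC3)cc2)cc1` carries methoxy in place of hydrogen on an aromatic carbon. Nothing measured isolates this change, so a step no larger than the scatter is expected, if anything toward tighter binding, giving a 1.5-fold lower number from compound 1 to compound 3 (0.17 log units; within the scatter). For compound 3 the estimate is 2500 nM, with a range of 800 nM to 8000 nM.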

Compound 3, dissociation constant: 3800 nM
The estimate for compound 3 lay 1.5-fold (0.18 log units) below the measured number, and the stated range covers the measured number.
By their numbers in this assay, from the lowest: compound 2; then compounds 1 and 3 (each within the scatter of the next).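

Swapping hydrogen for methoxy on this aromatic carbon, para to a large group, gives a 1.0-fold higher number from compound 1 to compound 3 (0.01 log units; within the scatter) in this assay. Compound 1 and compound 3 therefore cannot be told apart here, so this position accepts methoxy with no step beyond the scatter. No available evidence bears on the reason for this result.

As far as these compounds go, whether an amine, a carboxylic acid or a longer chain such as butoxy at this position would read differently remains open. It also remains open which of the several differences from compound 1 accounts for compound 2 at 21 nM.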